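Lengthening the Side Chain of Compound 2

The compounds below may be only part of what the source reports. "The series", "measured", "known", "first", "only" and "open" are said of these compounds alone.

Measured in a functional assay on HCT-116 cells (Homo sapiens) for antiproliferative activity, read by MTT assay, with a stated time of 48 h; a higher number here means a weaker inhibitor, a lower number a stronger inhibitor:
Compound 1 `CCCCCCCC(CCO)n1cnc2c(Cl)ncnc21`: 4160 nM
Compound 2 `CCCCCCCC(CCO)n1cnc2c(NC)ncnc21`: 12500 nM
Compound 3 `CCCCCCCC(CCO)n1cnc2c(N(C)C)ncnc21`: > 50000 nM, a limit of the assay

Compound 2 holds the higher of the two exact numbers, and compound 1 is its nearest neighbour. Compound 4 `CCCCCCCCCC(CCO)n1cnc2c(NC)ncnc21` differs from compound 2 by one change: ethyl in place of hydrogen on a saturated chain carbon, eight bonds along the chain from an aromatic nitrogen. Going by the values given here, no measured step touches this chain. Among the compounds with values here, the only guides to size come from another place on the shared core: a 3.0-fold higher number from compound 1 to compound 2 (0.48 log units; beyond the scatter), and an at least 4.0-fold higher number from compound 2 to compound 3 (0.60 log units; beyond the scatter). They bear on this change only loosely, so the direction is uncertain. The expected change is a 2.1-fold lower number from compound 2 to compound 4 (0.32 log units; beyond the scatter), a modest and tentative lean toward a lower number. The estimate for compound 4 is 6000 nM, with an expected range of 2000 nM to 20000 nM.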

Compound 4, half-maximal inhibitory concentration: 5410 nM
Compound 4: the middle estimate sits 1.1-fold (0.04 log units) above what was measured; the range from low to high includes it.
By their numbers in this assay, from the lowest: compounds 1 and 4 (each within the scatter of the next); then compound 2. At a limit, above all of these: compound 3.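

Going by these compounds alone, every earlier step lay at another place on the shared core, so this is the first reading from the side chain. In this assay, ethyl in place of hydrogen on a saturated chain carbon, eight bonds along the chain from an aromatic nitrogen, gives a 2.3-fold lower number from compound 2 to compound 4 (0.36 log units; beyond the scatter), so lengthening the chain here did not cost activity and brought a modest gain. Nothing measured here gives a reason for this step.

On these data alone, whether a still longer chain, or an amine or a carboxylic acid on this chain, would lower the number further remains open. So does whether the same ethyl change would have a similar effect with chloro or dimethylamino on the core.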